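The source may report more compounds than this note shows. Statements on the series, on what has been measured and on what is new or still open speak of the compounds shown alone.

Working notes on the series.

Within the data shown here, compound 1 `CCCCCCNc1nc(-c2ccccc2)nc2c1nnn2Cc1ccccc1` is one of three compounds with a number so far in an assay on isolated protein for binding affinity to adenosine receptor A1 (Bos taurus); a higher number here means a weaker inhibitor, a lower number a stronger inhibitor. In this assay compound 1 gives 13200000 nM, the second highest of the three. Compound 2 `OCCNc1nc(-c2ccccc2)nc2c1nnn2Cc1ccccc1` gives 38000000 nM in this assay, and the single-place step between them, a 2.9-fold higher number from compound 1 to compound 2 (0.46 log units; beyond the scatter), is hydroxy in place of butyl on a saturated chain carbon, two bonds along the chain from a nitrogen on an aromatic ring. Among the measured compounds shown here, compound 3 `FC(F)(F)c1ccccc1Cn1nnc2c(NC3CCCC3)nc(-c3ccccc3)nc21` gives 600000 nM in this assay; it differs from compound 1 in more than one place, so the two values show only that compound 3 sits far lower.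

Compound 4 `CCCCCCNc1nc(-c2ccccc2)nc2c1nnn2Cc1ccccc1Cl` differs from compound 1 by chloro in place of hydrogen on an aromatic carbon. For the measured compounds named here, no measured step changes only the benzyl ring, so nothing bears directly on this change. Going by the values given here, the only hint is compound 3, which carries trifluoromethyl on its benzyl ring, ortho to a large group, together with a different amine, and gives 600000 nM. The step from compound 1 to compound 4 in this assay is therefore expected to run toward a lower number, a 3.3-fold lower number from compound 1 to compound 4 (0.52 log units; beyond the scatter), with wide uncertainty. The estimate for compound 4 in this assay is 4000000 nM, between 1000000 nM and 15000000 nM.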

Compound 4, inhibition constant: 31000000 nM
Estimate against measurement, compound 4: 7.8-fold (0.89 log units) below; measured number above the stated range.
By their numbers in this assay, from the lowest: compound 3; then compound 1; then compounds 4 and 2 (each within the scatter of the next).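

In this assay, among these compounds, this is the first single-place reading for the benzyl group: a 2.3-fold higher number from compound 1 to compound 4 (0.37 log units; beyond the scatter), so going from benzyl to 2-chlorobenzyl raises the number when the amine of compound 1 is held fixed. This gives no support for reading the lower number of compound 3, 600000 nM, as a benefit of any group at this place on the ring, since compound 3 also carries a different amine and its trifluoromethyl cannot be separated from that change. No measurement on hand explains the direction of the chloro step, and the result stands as an observation on one pair.

Going by these compounds, it remains open whether chloro has the same effect alongside the cyclopentylamine of compound 3 or the hydroxyethylamine of compound 2, since this step has been read against a single amine. On these data alone, it is also open whether the amine or the trifluoromethyl accounts for the position of compound 3, a question that trifluoromethyl on the benzyl group of compound 1, or an unsubstituted benzyl group with the cyclopentylamine, would settle, and whether fluoro or methoxy at this place would follow chloro.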